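Chloro for methyl on the arylidene ring

This account rests on a few compounds, and the source may have more. Where it says the series, first, only, none or still open, it means among the compounds named here.

Measured so far in a functional assay on NCI-H460 cells (Homo sapiens) for inhibition, read by MTT assay, with a stated time of 72 h; on this read-out lower numbers stand for stronger inhibition of growth and higher numbers for weaker inhibition of growth:
compound 1 `COc1ccc(CNC(=O)/C(C#N)=C/c2ccc(C)o2)cc1`: > 100000 nM
compound 2 `COc1ccc(CNC(=O)/C(C#N)=C/c2ccc(Cl)o2)cc1`: 15000 nM
compound 3 `COc1ccc(CNC(=O)/C(C#N)=C/c2ccc(C)cc2)cc1`: 41000 nM

The value of compound 1 is a limit of this assay and not a number: the limit of > 100000 nM in this assay, at which 1 of the 3 values shown sits. Compound 2 gives a number in this assay, 15000 nM, and compound 3 gives 41000 nM.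

The change chloro in place of methyl on an aromatic carbon brings an at least 6.6-fold lower number from compound 1 to compound 2 (0.82 log units; beyond the scatter), the largest step in the set, though its full size is hidden by the limit. The cores differ as 4-methylphenyl in place of 5-methylfuran-2-yl on a double-bonded chain carbon bound to a double-bonded chain carbon, and this brings an at least 2.4-fold lower number from compound 1 to compound 3 (0.38 log units; beyond the scatter). Between the two numbered compounds, a 2.7-fold higher number from compound 2 to compound 3 (0.44 log units; beyond the scatter).

Compound 4 `COc1ccc(CNC(=O)/C(C#N)=C/c2ccc(Cl)cc2)cc1` is not yet measured. It differs from compound 3 by chloro in place of methyl on an aromatic carbon. This is the same kind of change as from compound 1 to compound 2, not the same: there the place was on an aromatic carbon of a five-membered aromatic ring with 1 oxygen, next to the ring oxygen, two ring bonds from the ring atom that bears a large group; here it is on an aromatic carbon of a six-membered aromatic ring of carbon only, para to a large group.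

For compound 4 a step of a 3.4-fold lower number from compound 3 to compound 4 (0.53 log units; beyond the scatter) in this assay is expected, resting on an at least 6.6-fold lower number from compound 1 to compound 2 (0.82 log units; beyond the scatter) and tempered by the different ring. Compound 4 is therefore estimated at 12000 nM, expected to lie between 4000 nM and 30000 nM.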

Compound 4, concentration for 50% growth inhibition: 14000 nM
Compound 4: middle estimate off by 1.2-fold (0.07 log units), on the low side; measured number inside the range.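

In this assay, chloro in place of methyl on the 4-methylphenyl core gives a 2.9-fold lower number from compound 3 to compound 4 (0.47 log units; beyond the scatter), so the change points the same way on both cores shown, and with chloro on each core the exchange of rings gives a 1.1-fold lower number from compound 2 to compound 4 (0.03 log units; within the scatter), which leaves 4-chlorophenyl and 5-chlorofuran-2-yl at values that cannot be told apart in this series, while 4-chlorophenyl in place of 5-methylfuran-2-yl gives an at least 7.1-fold lower number from compound 1 to compound 4 (0.85 log units; beyond the scatter). Compound 1 stands at > 100000 nM, which is a limit of the assay and not a number, so the steps from it cannot be read for their full size. The direction of the change therefore carries from one core to the other, but nothing shows that its size carries with it, and two cores are too few to call this a general rule: the same change on two cores in this assay, an at least 6.6-fold lower number (0.82 log units; beyond the scatter) from compound 1 to compound 2 and a 2.9-fold lower number (0.47 log units; beyond the scatter) from compound 3 to compound 4; the limit leaves it open whether they differ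

The compounds shown leave open whether bromo, fluoro or trifluoromethyl on the same ring carbon would follow chloro or methyl on either core. They also leave open whether the chloro result holds when the nitrile gives way to a carboxylic acid, or when an amine or a longer chain is carried on the amide side of the shared core.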